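The source may hold more compounds than are shown below. What is called first, only, known or untested is meant among the compounds shown, and "the series" means these compounds.

Compound 1, `COc1cc(/C=C/C2=CC(=O)CC(c3ccc(O)c(OC)c3)N2CCCO)ccc1O`, was tested in a functional assay on HT-29 cells (Homo sapiens) for cytotoxicity, read by MTT assay, with a stated time of 48 h (a higher number here means a weaker inhibitor, a lower number a stronger inhibitor), and for compound 1 the result is a limit rather than a number, > 100000 nM. Compound 2, `COCCCNC(=C\C(=O)/C=C/c1ccc(O)cc1)/C=C/c1ccc(O)cc1`, gives 51900 nM in this assay, which is the only finite number among the two results shown; the other result sits at the limit of > 100000 nM in this assay, at which 1 of the 2 values shown sits. Compound 3, `O=C(/C=C(/C=C/c1ccc(O)cc1)NCCO)/C=C/c1ccc(O)cc1`, has not yet been measured in this assay. It differs from compound 2 in one place: hydroxy in place of methoxymethyl on a saturated chain carbon, two bonds along the chain from an amine nitrogen. Going by the values given here, since no measured pair of compounds traces this change, there is no measured step to lean on. The change is small in size and keeps the rest of the structure intact, so the step from compound 2 to compound 3 is expected to stay within the usual scatter, with a 1.0-fold lower number from compound 2 to compound 3 (0.02 log units; within the scatter) in this assay. Compound 3 is therefore estimated to give about 50000 nM in this assay, with a likely range from 20000 nM to 130000 nM.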

Compound 3, half-maximal inhibitory concentration: 66200 nM
The estimate for compound 3 lay 1.3-fold (0.12 log units) below the measured number, and the stated range covers the measured number.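

Going by these compounds alone, the first measured step at this position is a 1.3-fold higher number from compound 2 to compound 3 (0.11 log units; within the scatter) in this assay, with (3-methoxypropyl)amino giving way to (2-hydroxyethyl)amino. It shows that, on this core, the chain on the amine nitrogen can be shortened and its methyl ether end exchanged for a free hydroxy without the result moving beyond the scatter. None of the data shown bears on why this exchange leaves the result within the scatter.

This is a single step in a single assay, so it does not show whether an amine or a carboxylic acid at the chain end, or a longer chain, would be accommodated in the same way. It also leaves open whether the same exchange would behave alike on the core of compound 1.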